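Chalcone-pyrazole series: third methoxy on the aryl ring

The compounds below may be only part of what the source reports. "The series", "measured", "known", "first", "only" and "open" are said of these compounds alone.

Measured so far in a functional assay on K562 cells (Homo sapiens) for inhibition, read by sulforhodamine B assay, with a stated time of 48 h; on this read-out lower numbers stand for stronger inhibition of growth and higher numbers for weaker inhibition of growth:
compound 1 `COc1cc(-c2cc(/C=C/C(=O)c3ccc(N)cc3)[nH]n2)cc(OC)c1OC`, 720 nM
compound 2 `COc1ccc(-c2cc(/C=C/C(=O)c3cc(OC)c(OC)c(OC)c3)[nH]n2)cc1OC`, 730 nM

Compound 2 gives a number that cannot be separated from that of compound 1; the two values sit within the scatter of each other, so no order between them can be read.

Compound 3 `COc1cc(C(=O)/C=C/c2cc(-c3cc(OC)c(OC)c(OC)c3)n[nH]2)cc(OC)c1OC` is not yet measured. It differs from compound 2 by methoxy in place of hydrogen on an aromatic carbon. Going by the values given here, no step between measured compounds shows the effect of this change, so the size and direction of the step are open; the expectation is a step no larger than the scatter, a 1.2-fold lower number from compound 2 to compound 3 (0.09 log units; within the scatter), in this assay.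

Compound 3 is expected to give about 600 nM, estimated between 200 nM and 1500 nM.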

Compound 3, concentration for 50% growth inhibition: 2960 nM
Beside the measured number, compound 3's estimate is 4.9-fold (0.69 log units) below it, and the stated range ends below it.
By their numbers in this assay, from the lowest: compounds 1 and 2 (each within the scatter of the next); then compound 3.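

In this assay, methoxy in place of hydrogen on this aromatic carbon, ortho to a methoxy group, gives a 4.1-fold higher number from compound 2 to compound 3 (0.61 log units; beyond the scatter) and so is not a silent change. Going by these compounds alone, this is the first step that isolates a single position, and it shows that the number responds to substitution at this carbon, with hydrogen giving the lower number of the two. Nothing available here accounts for the step.

On these data alone, whether fluorine or hydroxyl at this carbon would stay close to compound 2 remains open. So does whether a longer chain such as ethoxy would move the number further.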